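Halogen to nitro step on a shared dibromo core

The source may hold more compounds than are shown below. What is called first, only, known or untested is meant among the compounds shown, and "the series" means these compounds.

Measured compounds:
Compound 1 `O=C1CC(c2ccc(F)cc2)Nc2c(Br)cc(Br)cc21`: in a functional assay on MCF7 cells (Homo sapiens) for cytotoxicity, read by sulforhodamine B assay, with a stated time of 48 h (a higher number here means that more compound is tolerated, a lower number that less compound is tolerated), compound 1 gives > 100000 nM, which is a limit of the assay and not a number.
Compound 2 `O=C1CC(c2ccc(Cl)cc2)Nc2c(Br)cc(Br)cc21`: in this assay compound 2 gives > 100000 nM, likewise a limit.
Compound 3 `O=C1CC(c2ccc(Br)cc2)Nc2c(Br)cc(Br)cc21`: in this assay compound 3 gives > 100000 nM, again a limit.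

Compound 3 stands where the whole measured set stands, at the limit of > 100000 nM in this assay, at which 3 of the 3 values shown sit. The three measured steps, a step that the two limits leave unreadable from compound 1 to compound 2, a step that the two limits leave unreadable from compound 1 to compound 3 and a step that the two limits leave unreadable from compound 2 to compound 3, each exchange one halogen for another on the aromatic carbon and none has a readable size, since both ends sit at the limit. Compound 4 `O=C1CC(c2ccc([N+](=O)[O-])cc2)Nc2c(Br)cc(Br)cc21` is the unmeasured member; it differs from compound 3 by nitro in place of bromo on an aromatic carbon. Among the compounds with values here, no measured step involves a nitro group, so the measured halogen swaps bear on the new step only in that every change at this position so far left the compound at the limit. The step from compound 3 to compound 4 is therefore expected to be a number no higher from compound 3 to compound 4 (the limit leaves the size open), with nothing beyond the scatter foreseen in this assay. For compound 4 the estimate in this assay is 100000 nM, with a range from 30000 nM to 300000 nM, and a report of only a limit is the likelier outcome.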

Compound 4, concentration lethal to 50% of the cells: > 100000 nM
Compound 4 ended at the assay's limit; the forecaster's own chance of this, stated with the estimate: 75%; the middle value lies on the limit itself.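

The steps from compound 1, compound 2 and compound 3 to compound 4 cannot be read in this assay, because every value is a limit and not a number: the limit of > 100000 nM in this assay, at which 4 of the 4 values shown sit.

The compounds shown leave open whether these four compounds differ at all in this assay, and whether any group at this position on the shared core gives a readable value.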